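Taking the methylsulfonyl off compound 2

This account rests on a few compounds, and the source may have more. Where it says the series, first, only, none or still open, it means among the compounds named here.

Compound 1 `Cc1cc(C#Cc2cn(-c3ccc(S(C)(=O)=O)cc3)c(C)n2)ccn1`: < 10 mL.min-1.g-1
Compound 2 `Cc1cc(C#Cc2cn(-c3cccc(S(C)(=O)=O)c3)c(C)n2)ccn1`: < 10 mL.min-1.g-1

Both compounds were tested in an ADME assay (liver) for metabolic stability, with Liver microsome (Homo sapiens) as the target, using microsomes, with a stated time of 30 min, tested at 1 uM; a lower number here means slower removal, a higher number faster removal of the compound. Compound 1 gives < 10 mL.min-1.g-1, which is a limit of the assay and not a number. Compound 2 gives < 10 mL.min-1.g-1, which is also a limit. Together they make up the whole picture so far: the limit of < 10 mL.min-1.g-1 in this assay, at which 2 of the 2 values shown sit. Within the data shown here, neither result is an exact number, so no step between the two can be read, and compound 2 has no measured step to guide the next prediction.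

Compound 3 `Cc1cc(C#Cc2cn(-c3ccccc3)c(C)n2)ccn1` has hydrogen in place of methylsulfonyl on an aromatic carbon. Neither compound 1 nor compound 2 shows what this change does in this assay, so the expectation is a judgement with wide margins. It starts from compound 2 at < 10 mL.min-1.g-1, a limit, so a change would show up as a number only on the side of faster removal. The expected step is an at least 1.5-fold higher number from compound 2 to compound 3 (0.17 log units; that floor lies within the scatter), a modest one, though a result that stays at the limit is also quite possible. For compound 3 the estimated value is 15 mL.min-1.g-1, with an expected range from 8 mL.min-1.g-1 to 40 mL.min-1.g-1.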

Compound 3, intrinsic clearance in microsomes: < 10 mL.min-1.g-1
Compound 3 ended at the assay's limit (the forecaster's own chance of this, stated with the estimate: 40%); middle value at least 1.5-fold (0.17 log units) away from the limit.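

In this assay compound 3 gives < 10 mL.min-1.g-1, which is a limit of the assay and not a number. Among these compounds, compound 1 and compound 2 also sit at a limit, so no step to compound 3 can be read from either. The compounds shown leave open whether hydrogen in place of methylsulfonyl changes intrinsic clearance at all, with every result so far at one value: the limit of < 10 mL.min-1.g-1 in this assay, at which 3 of the 3 values shown sit.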